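A Distant Swap on the Aryl Ether

The source may report more compounds than this note shows. Statements on the series, on what has been measured and on what is new or still open speak of the compounds shown alone.

Compound 1 `COc1ccccc1Oc1ccc2c(NCCCNCc3ccco3)ccnc2c1` belongs to a set of three measured compounds built on a shared core. In a physicochemical assay for acid dissociation, compound 1 gives 9.28. Compound 2 `COc1cccc(Oc2ccc3c(NCCCNCc4cc(F)ccc4OC)ccnc3c2)c1` gives 9.28 in this assay, and compound 3 `COc1ccc(Oc2ccc3c(NCCCNCc4cccc(OC)c4O)ccnc3c2)cc1` gives 9.28. Compound 1 therefore stands level with compound 2 and with compound 3 at the digits shown, all within the usual scatter, so no order among the three can be claimed.

Compound 4 `Fc1ccc(Oc2ccc3c(NCCCNCc4ccco4)ccnc3c2)cc1` has not yet been measured. It differs from compound 1 in a single place: 4-fluorophenyl in place of 2-methoxyphenyl on an oxygen on an aromatic ring. Among compounds 1, 2 and 3, different groups on that same oxygen went with values that lie within the scatter of one another. For the measured compounds named here, no step between measured compounds exists for this exact exchange, so the expectation rests on that observation alone. The step of no change at the digits printed from compound 1 to compound 4 (within the scatter) is expected to be none beyond the scatter. Compound 4 is estimated at 9.28, with a range from 8.95 to 9.6.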

Compound 4, acid dissociation constant: 9.28
Estimate against measurement, compound 4: no gap at the digits printed; the range from low to high includes it.
By their numbers in this assay, from the lowest: compounds 1, 2, 3 and 4 (each within the scatter of the next).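

For the compounds shown here, compounds 1, 2 and 3 differed in more than one place, so this is the first change that can be read on its own: in this assay, replacing 2-methoxyphenyl with 4-fluorophenyl on an oxygen on an aromatic ring gives no change at the digits printed from compound 1 to compound 4 (within the scatter). The exchange goes from 8 heavy atoms to 7 and from 1 hydrogen-bond acceptor to 0, yet the two values remain within the scatter of each other. No measurement shown bears on the reason for this result.

Going by these compounds alone, this single step covers only one pair of groups at this position. Going by these compounds, whether an aminoalkyl group or a carboxylic acid on the aryl ring, or a longer chain in its place on that oxygen, would also stay within the scatter remains open.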